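Cyclopentyl for isopropyl on the ketone chain of compound 1

This account rests on a few compounds, and the source may have more. Where it says the series, first, only, none or still open, it means among the compounds named here.

Among the three compounds measured in an assay on HEK293 cells for positive allosteric modulation of metabotropic glutamate receptor 3 (Rattus norvegicus), read by thallium flux, with a stated time of 2.5 min (a higher number here means a larger maximal response, a lower number a smaller maximal response), compound 1 `Cc1cc(C(=O)O)ccc1OCCCCOc1ccc(C(=O)CC(C)C)c(O)c1C` stands second highest. In this assay compound 1 gives 42.1%. Compound 3 `Cc1c(OCCCCOc2ccc(C(=O)O)c(Cl)c2)ccc(C(=O)CC(C)C)c1O` gives 49.5%, and the two lie within the scatter of one another, the step being a number 7.4 percentage points higher from compound 1 to compound 3 (within the scatter). Compound 2 `COC(=O)c1ccc(OCCCCOc2ccc(C(=O)CC(C)C)c(O)c2C)cc1` gives 22.7%; the step of a number 19.4 percentage points lower from compound 1 to compound 2 (beyond the scatter) lies beyond the scatter, as does a number 26.8 percentage points higher from compound 2 to compound 3 (beyond the scatter).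

Compound 4 `Cc1cc(C(=O)O)ccc1OCCCCOc1ccc(C(=O)CC2CCCC2)c(O)c1C` is the unmeasured compound. It differs from compound 1 in a single place: cyclopentyl in place of isopropyl on a saturated chain carbon bound to a carbonyl carbon. None of the three measured steps bears on this change. Each of them alters the group on an oxygen on a saturated carbon, that is, the carboxy-bearing aryl end, whereas the change to compound 4 sits on a saturated chain carbon bound to a carbonyl carbon, at the ketone end that all three measured compounds share unchanged. Within the data shown here, there is therefore no measured precedent for this exchange, and the only sound expectation is a step of no particular direction, staying within the scatter.

Compound 4 is accordingly expected to give about 42% in this assay, with a range from 26% to 58%. This estimate means a step of a number 0.1 percentage points lower from compound 1 to compound 4 (within the scatter), expected to fall within the scatter.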

Compound 4, largest response reached (reported as percent of maximum), in percent of the reference or control that the assay uses: 28.4%
Compound 4: middle estimate off by 13.6 percentage points, on the high side; the range from low to high includes it.
By their numbers in this assay, from the lowest: compounds 2 and 4 (each within the scatter of the next); then compounds 1 and 3 (each within the scatter of the next).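

The ketone end of the core is not silent in this assay: with cyclopentyl in place of isopropyl on a saturated chain carbon bound to a carbonyl carbon, the step is a number 13.7 percentage points lower from compound 1 to compound 4 (beyond the scatter). Among these compounds, all the earlier steps altered the group on an oxygen on a saturated carbon, so this is the first sign that the maximal response also depends on the group at this other place, and that here the larger, ring-bearing group gives the lower response. No measurement shown here accounts for this step.

From the compounds shown here alone, a single exchange cannot separate the effect of the ring from that of the added carbons, so it stays open whether a smaller ring such as cyclopropyl or cyclobutyl, an open chain such as neopentyl or n-pentyl, or an oxygen-bearing ring such as tetrahydrofuranyl would hold the response of compound 1 or lower it further. Going by these compounds, it also stays open whether cyclopentyl would give a step of similar size on the core of compound 3, which carries the 4-carboxy-3-chlorophenyl group.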